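The source may hold more compounds than are shown below. What is called first, only, known or untested is meant among the compounds shown, and "the series" means these compounds.

Measured compounds in this study:

- compound 1 `C=CC(=O)NCc1ccc(C(=O)Nc2ccc(C)c(Nc3nccc(-c4cccnc4)n3)c2)cc1`: in an ADME assay on BaF3 cells (Mus musculus) for cytotoxicity, read by CellTiter-Glo and CCK-8 assay, with a stated time of 72 h (a higher number here means a weaker inhibitor of growth, a lower number a stronger inhibitor of growth), compound 1 gives > 10000 nM, which is a limit of the assay rather than a number.
- compound 2 `C=CC(=O)NCc1ccc(C(=O)Nc2ccc(C)c(Nc3nccc(-c4cccnc4)n3)c2)cc1C(F)(F)F`: in this assay compound 2 gives > 10000 nM, again only a limit.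
- compound 3 `CCC(=O)Nc1cc(C(=O)Nc2ccc(C)c(Nc3nccc(-c4cccnc4)n3)c2)cc(C(F)(F)F)c1`: in this assay compound 3 gives > 10000 nM, also a limit.

Compound 1 therefore stands at the edge of what this assay can report, and no exact number for it is known. Within the data shown here, the one measured step between single-change neighbours, a step that the two limits leave unreadable from compound 1 to compound 2, runs from one limit to another, so its size cannot be read.

Compound 4 `C/C=C/C(=O)N(CCN(C)C)Cc1ccc(C(=O)Nc2ccc(C)c(Nc3nccc(-c4cccnc4)n3)c2)cc1` differs from compound 1 by (2-(dimethylamino)ethyl)((prop-1-en-1-yl)carbonyl)amino in place of (vinylcarbonyl)amino on a saturated chain carbon bound to an aromatic carbon. Among the measured compounds shown here, no measured step touches this part of the molecule, so nothing can be inferred about its direction or size; the only guidance is the limit of > 10000 nM in this assay, at which 3 of the 3 values shown sit. On that basis compound 4 is expected to remain at the limit as well, with the expected step that the limit leaves unreadable from compound 1 to compound 4 being no more than scatter. The estimate for compound 4 is 15000 nM, in a range from 7000 nM to 40000 nM.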

Compound 4, concentration for 50% growth inhibition: > 10000 nM
Compound 4 ended at the assay's limit; the forecaster's own chance of this, stated with the estimate: 80%; the middle value does not contradict the limit.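

No step can be read from compound 1 to compound 4, since in this assay both compounds give a limit and not a number: the limit of > 10000 nM in this assay, at which 4 of the 4 values shown sit. The compounds shown leave open how strongly each inhibits growth, and so whether any of these structural changes alters it.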